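The source may report more compounds than this note shows. Statements on the series, on what has been measured and on what is new or still open speak of the compounds shown alone.

Of the compounds shown here, three of one family have been tested in a functional assay on L1210 cells (Mus musculus) for inhibition, read by cell counting, with a stated time of 2 days; a lower number here means a stronger inhibitor, a higher number a weaker inhibitor. Compound 1, `Nc1cccc(-c2cn3c(-c4ccc(Cl)cc4)csc3n2)c1`, gives 22000 nM in this assay. Compound 3, `COc1cccc(Cc2nn3cc(-c4cccc(N)c4)nc3s2)c1`, gives 21000 nM in this assay, and these two numbers sit within the usual scatter of each other, so neither compound can be called the stronger one. Compound 2, `Nc1cccc(-c2cn3nc(-c4ccc(F)cc4)sc3n2)c1`, reaches only >= 250000 nM in this assay, which is a limit of the assay and not a number. That value is the limit of >= 250000 nM in this assay, at which 1 of the 3 values shown sits, so compound 2 stands apart from the other two without a number of its own.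

The next compound, compound 4, `Nc1cccc(-c2cn3c(-c4ccccc4)csc3n2)c1`, has not yet been measured. It differs from compound 1 in one place: hydrogen in place of chloro on an aromatic carbon. For the measured compounds named here, no pair of measured compounds shows this same change, so there is no measured step to lean on. Removing one chlorine from a phenyl group is a small change to the whole molecule, and the expectation is a step of modest size, if any, most likely toward a slightly weaker inhibitor. The expected step of a 1.6-fold higher number from compound 1 to compound 4 (0.20 log units; within the scatter) is therefore estimated to stay close to the scatter. Compound 4 is expected to give about 35000 nM in this assay, with a likely range from 12000 nM to 110000 nM.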

Compound 4, half-maximal inhibitory concentration: 85000 nM
Estimate against measurement, compound 4: 2.4-fold (0.39 log units) below, and the stated range covers the measured number.
By their numbers in this assay, from the lowest: compounds 3 and 1 (each within the scatter of the next); then compound 4. At a limit, above all of these: compound 2.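

In this assay, for the compounds shown here, the change from 4-chlorophenyl to phenyl is the first in this family that can be read as a single step, and it gives a 3.9-fold higher number from compound 1 to compound 4 (0.59 log units; beyond the scatter), with everything else in the molecule held the same. The position on the aromatic carbon para to a large group is therefore not indifferent to what sits there: of this pair, the compound that keeps the chlorine is the stronger inhibitor, although the step is only modest in size and rests on one pair of compounds. Going by these compounds alone, the one piece of supporting information available concerns a different compound and has no bearing on why this change matters, so the step stands here without an explanation.

From the compounds shown here alone, only chloro and hydrogen are compared at this place, so it remains open whether a larger halogen such as bromo, a methyl group, a methoxy group or an amine would match the chlorine, surpass it or fall short. Going by these compounds, it also remains open whether the same change would give a step of similar size on a different core.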